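Clearance notes on the substituted core: chloro to cyano

The source may hold more compounds than are shown below. What is called first, only, known or untested is meant among the compounds shown, and "the series" means these compounds.

Measured so far:
compound 1 `CC(=O)N[C@@H]1CCC[C@H](C(=O)Nc2cc(-c3cnn4c3CC(C)(C)C4)ccn2)C1`: 45 uL/min
compound 2 `CC(=O)N[C@@H]1CCC[C@H](C(=O)Nc2cc(-c3cnn4c3CC(C)(C)C4)c(F)cn2)C1`: 81 uL/min
compound 3 `CC(=O)N[C@@H]1CCC[C@H](C(=O)Nc2cc(-c3cnn4c3CC(C)(C)C4)c(Cl)cn2)C1`: 73 uL/min

In an ADME assay on cells (Hepatocyte, Rattus norvegicus) for metabolic stability, using equilibrium dialysis (on this read-out lower numbers stand for slow clearance and higher numbers for fast clearance), compound 3 stands second highest of the three numbers; its nearest neighbour is compound 2 and its furthest is compound 1, and both gaps lie within the scatter, so no order among the three can be read. Compound 4 `CC(=O)N[C@@H]1CCC[C@H](C(=O)Nc2cc(-c3cnn4c3CC(C)(C)C4)c(C#N)cn2)C1` differs from compound 3 in one place: cyano in place of chloro on an aromatic carbon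

Within the data shown here, two measured steps touch the same aromatic carbon. From hydrogen to chloro, a 1.6-fold higher number from compound 1 to compound 3 (0.21 log units; within the scatter). From fluoro to chloro, a 1.1-fold lower number from compound 2 to compound 3 (0.05 log units; within the scatter). Among the measured compounds shown here, neither leaves the scatter, and no measured step introduces a cyano group anywhere, so the present change has no direct precedent. The cyano group brings one hydrogen-bond acceptor that chloro lacks, but what that does in this assay is not shown by any measured pair.

On that basis no step beyond the scatter is expected for compound 4, and the estimated change is a 1.2-fold lower number from compound 3 to compound 4 (0.09 log units; within the scatter). Compound 4 is therefore expected to give about 60 uL/min in this assay, with a range from 30 uL/min to 120 uL/min.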

Compound 4, intrinsic clearance in a liver preparation (reported as CLH), per the amount of preparation that the assay uses: 47 uL/min
Beside the measured number, compound 4's estimate is 1.3-fold (0.11 log units) above it; the measured number falls inside the stated range.
By their numbers in this assay, from the lowest: compounds 1, 4, 3 and 2 (each within the scatter of the next).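

With cyano on this aromatic carbon, ortho to a large group and two atoms from the ring nitrogen, the four groups tried there (hydrogen, fluoro, chloro and cyano) all lie within the scatter of one another in this assay. Among these compounds, this holds for the first step involving a nitrile, whether it replaces chloro (a 1.6-fold lower number from compound 3 to compound 4 (0.19 log units; within the scatter)), fluoro (a 1.7-fold lower number from compound 2 to compound 4 (0.24 log units; within the scatter)) or hydrogen (a 1.0-fold higher number from compound 1 to compound 4 (0.02 log units; within the scatter)), so adding a triple bond and a hydrogen-bond acceptor at this carbon produces no step that can be read as real. No measurement at hand accounts for this outcome or links it to any property of the group.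

From the compounds shown here alone, whether an amine, a carboxylic acid or a methoxy group on this same carbon would move the clearance number beyond the scatter remains open. Also open, going by these compounds, is whether hydrogen, fluoro, chloro and cyano would stay this close to one another once another part of the shared core is changed.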